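Extending the tert-butyl of compound 3 into a branched chain

This account rests on a few compounds, and the source may have more. Where it says the series, first, only, none or still open, it means among the compounds named here.

Compound 1, `COc1ccc(Cc2cnc(CCc3ccc(-c4ccccc4C(=O)O)cc3)[nH]2)cc1`: 513 nM
Compound 2, `O=C(O)c1ccccc1-c1ccc(CCc2ncc(CC3CC3)[nH]2)cc1`: 72 nM
Compound 3, `CC(C)(C)c1cnc(CCc2ccc(-c3ccccc3C(=O)O)cc2)[nH]1`: 2750 nM

In an in vitro functional assay on cells for agonist activity at Bombesin receptor subtype-3 (Mus musculus), read by luminescence and calcium flux (a lower number here means that less compound is needed, a higher number that more compound is needed for the effect), compound 3 gives the highest number of the three. Compound 4, `CCC(C)(CC)Cc1cnc(CCc2ccc(-c3ccccc3C(=O)O)cc2)[nH]1`, carries 2-ethyl-2-methylbutyl in place of tert-butyl on an aromatic carbon. For the measured compounds named here, two measured steps bear on this change. The step of a 38-fold higher number from compound 2 to compound 3 (1.58 log units; beyond the scatter) and the step of a 5.4-fold higher number from compound 1 to compound 3 (0.73 log units; beyond the scatter) both show the tert-butyl of compound 3 giving a clearly higher number than a larger group on the same ring carbon. The 2-ethyl-2-methylbutyl of compound 4 is again a larger group, so a lower number than that of compound 3 is expected, by a step of a 9.2-fold lower number from compound 3 to compound 4 (0.96 log units; beyond the scatter) in this assay. Compound 4 is therefore estimated at 300 nM, within a range of 60 nM to 1500 nM.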

Compound 4, half-maximal effective concentration: 30 nM
Compound 4: the middle estimate sits 10-fold (1.00 log units) above what was measured, and the stated range ends above it.
By their numbers in this assay, from the lowest: compound 4; then compound 2; then compound 1; then compound 3.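

In this assay, the 2-ethyl-2-methylbutyl group reverses the poor result of the tert-butyl, giving a 92-fold lower number from compound 3 to compound 4 (1.96 log units; beyond the scatter), the largest step yet at this ring carbon. Compound 4 also passes both earlier groups on a saturated chain carbon, with a 2.4-fold lower number from compound 2 to compound 4 (0.38 log units; beyond the scatter) and a 17-fold lower number from compound 1 to compound 4 (1.23 log units; beyond the scatter), so a 1-ethyl-1-methylpropyl on that carbon is better here than cyclopropyl or 4-methoxyphenyl. Compounds 1, 2 and 4 all carry that chain carbon and all lie below compound 3, which lacks it.

On these data alone, whether an unbranched chain such as n-pentyl would do as well remains open. Nothing given here explains the size of these steps.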